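This account rests on a few compounds, and the source may have more. Where it says the series, first, only, none or still open, it means among the compounds named here.

Measured so far:
compound 1 `O=C1C=CCC(/C=C/c2ccc(C(F)(F)F)cc2)O1`: 54.8 uM
compound 2 `O=C1C=CCC(/C=C/c2ccccc2)N1`: 967 uM

In a functional assay on NCI/ADR cells (Homo sapiens) for inhibition, read by sulforhodamine B assay, with a stated time of 48 h (on this read-out lower numbers stand for stronger inhibition of growth and higher numbers for weaker inhibition of growth), compound 1 gives 54.8 uM, while compound 2 gives 967 uM, the higher of the two numbers; the gap between them lies beyond the usual scatter. No single step is shown between these two, since they differ in more than one place. Compound 3, `O=C1C=CCC(/C=C/c2ccccc2C(F)(F)F)N1`, has not yet been measured. It differs from compound 2 by trifluoromethyl in place of hydrogen on an aromatic carbon. Only the two values above can guide an expectation: compound 1 carries a trifluoromethyl group and gives the lower number, yet it also differs from compound 2 elsewhere, so the gap cannot be laid on the trifluoromethyl group alone. A moderate downward step is therefore expected from compound 2 to compound 3 in this assay, a 2.4-fold lower number from compound 2 to compound 3 (0.38 log units; beyond the scatter), with wide uncertainty. Compound 3 is estimated at 400 uM, within a range from 120 uM to 1300 uM.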

Compound 3, concentration for growth inhibition (reported as GI): 40.6 uM
The estimate for compound 3 lay 9.9-fold (0.99 log units) above the measured number, outside the stated range (below it).
By their numbers in this assay, from the lowest: compounds 3 and 1 (each within the scatter of the next); then compound 2.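

In this assay, trifluoromethyl in place of hydrogen on an aromatic carbon, ortho to a group of 9 heavy atoms, gives a 24-fold lower number from compound 2 to compound 3 (1.38 log units; beyond the scatter) for this single change. Compounds 1 and 2 differ in more than one place and could not show this, whereas here the large drop in the number can be tied to one group at one position of the six-membered aromatic ring. No measurement accompanying these compounds accounts for the size of this step.

The compounds shown leave open whether a methyl group, a chlorine atom or a nitrile at this position would give a similar step. Compound 1 also carries trifluoromethyl at another ring position, but it differs elsewhere too, so the effect of moving the group on the core of compound 3 remains unresolved.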